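The source may report more compounds than this note shows. Statements on the series, on what has been measured and on what is new or still open speak of the compounds shown alone.

The measured compounds stand as follows. Compound 1, `CCN(CC)CCCOc1cc2ncnc(Nc3ccc(C#N)cc3)c2cc1OC`: in a functional assay on SH-SY5Y cells (Homo sapiens) for antiproliferative activity, read by MTT assay, with a stated time of 72 h (a lower number here means a stronger inhibitor, a higher number a weaker inhibitor), compound 1 reaches only the assay limit, > 100000 nM. Compound 2, `COc1cc2c(Nc3ccc(C#N)cc3)ncnc2cc1OCCCN1CCC(C)CC1`: in this assay compound 2 gives 7900 nM. Compound 3, `COc1cc2c(Nc3ccc(C#N)cc3)ncnc2cc1OCCCN1CCCCC1CCO`: in this assay compound 3 reaches only the assay limit, > 100000 nM.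

Compound 3 therefore sits at the limit of > 100000 nM in this assay, at which 2 of the 3 values shown sit; the step that the two limits leave unreadable from compound 1 to compound 3, while the step of an at least 12-fold higher number from compound 2 to compound 3 (1.10 log units; beyond the scatter). Compound 4, `COc1cc2c(Nc3ccc(C#N)cc3)ncnc2cc1OCCCN1CCC(c2ccccc2)CC1`, differs from compound 3 in one place: 4-phenylpiperidin-1-yl in place of 2-(2-hydroxyethyl)piperidin-1-yl on a saturated chain carbon, three bonds along the chain from an oxygen on an aromatic ring. For the measured compounds named here, the steps that bear on this change are an at least 12-fold lower number from compound 1 to compound 2 (1.10 log units; beyond the scatter) and an at least 12-fold higher number from compound 2 to compound 3 (1.10 log units; beyond the scatter), both large and both favouring a piperidine without the hydroxyethyl arm. Compound 4 is therefore expected to show an at least 12-fold lower number from compound 3 to compound 4 (1.09 log units; beyond the scatter). Compound 4 is estimated at 8000 nM, with a range from 1500 nM to 50000 nM.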

Compound 4, half-maximal inhibitory concentration: 7770 nM
Compound 4: middle estimate off by 1.0-fold (0.01 log units), on the high side; low and high end bracket the measured number.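

Phenyl in place of methyl on a saturated ring carbon leaves the result in this assay within the scatter, with a 1.0-fold lower number from compound 2 to compound 4 (0.01 log units; within the scatter). The larger 4-phenylpiperidin-1-yl group therefore gives large steps of the kind seen with 4-methylpiperidin-1-yl, namely an at least 12-fold lower number from compound 3 to compound 4 (1.10 log units; beyond the scatter) and an at least 12-fold lower number from compound 1 to compound 4 (1.10 log units; beyond the scatter). Both steps start from an assay limit: the limit of > 100000 nM in this assay, at which 2 of the 4 values shown sit.

As far as these compounds go, whether 4-(2-hydroxyethyl)piperidin-1-yl or morpholin-4-yl on the same chain carbon would match compound 2 and compound 4 or reach the limit stays open.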